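Swapping a fluoropyridyl for fluorophenyl on a tetrazole-bearing core

The compounds below may be only part of what the source reports. "The series", "measured", "known", "first", "only" and "open" are said of these compounds alone.

Of the compounds shown here, two with a shared core have been measured in a functional assay on cells for antagonist activity at Orexin/Hypocretin receptor type 1 (Homo sapiens), read by fluorescence and calcium flux, with a stated time of 30 min; on this read-out higher numbers stand for weaker inhibition and lower numbers for stronger inhibition. Compound 1 `CCN(C(=O)c1cc(C)ccc1-n1nccn1)[C@H](C)Cn1ccc(-c2ccc(F)cn2)n1` gives 86.6 nM in this assay. Compound 2 `CCN(C(=O)c1cc(C)ccc1-n1nccn1)[C@@H](C)Cn1nnc(-c2ccc(F)cn2)n1` gives 1.1 nM in this assay, the lower of the two numbers, and the gap between compound 1 and compound 2 lies well beyond the usual scatter of repeated measurements. Compound 2 therefore stands as the stronger inhibitor of the pair.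

Compound 3 `CCN(C(=O)c1cc(C)ccc1-n1nccn1)[C@@H](C)Cn1nnc(-c2ccc(F)cc2)n1` has not yet been measured. It differs from compound 2 in one place: 4-fluorophenyl in place of 5-fluoropyridin-2-yl on an aromatic carbon. Among the measured compounds shown here, no single-change step between two measured compounds is available to calibrate this exchange, so the expectation rests on the value of compound 2 alone and on the modest size of the change, which swaps one six-membered aromatic ring for another and removes one hydrogen-bond acceptor.

Compound 3 is expected to give 3 nM in this assay, with a plausible range from 0.8 nM to 15 nM. The estimated step of a 2.7-fold higher number from compound 2 to compound 3 (0.44 log units; beyond the scatter) is expected to be small and toward weaker inhibition, close to the edge of the scatter.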

Compound 3, half-maximal inhibitory concentration: 0.82 nM
Compound 3: the middle estimate sits 3.7-fold (0.56 log units) above what was measured; the range from low to high includes it.
By their numbers in this assay, from the lowest: compounds 3 and 2 (each within the scatter of the next); then compound 1.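

In this assay, the exchange of 5-fluoropyridin-2-yl for 4-fluorophenyl on an aromatic carbon of the five-membered aromatic ring with 4 nitrogen gives a 1.3-fold lower number from compound 2 to compound 3 (0.13 log units; within the scatter), so this read-out does not tell the two compounds apart. The change removes the ring nitrogen and the hydrogen-bond acceptor counted with it, yet a ring of carbon only serves as well here, which shows that on this core the nitrogen is not required at this position for a number of this size. Nothing in the data shown bears on why the exchange leaves the number within the scatter.

As far as these compounds go, whether the fluorine itself matters remains open, as does how a plain phenyl, a 4-chlorophenyl, a 4-methoxyphenyl or a saturated cyclohexyl ring would read at this place. Also open, from the compounds shown here alone, is whether the same exchange would read alike on the core of compound 1, which differs from compound 2 in more than one place, so that its number cannot be tied to any single change.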